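Swapping the sulfonamide aryl group in a piperidine series

This account rests on a few compounds, and the source may have more. Where it says the series, first, only, none or still open, it means among the compounds named here.

Three compounds share a core built from an aminochlorophenyl ketone joined through a short chain to a piperidine, which in turn carries a sulfonamide. In an assay on HEK293 cells for displacement of a labelled ligand from 5-hydroxytryptamine receptor 6 (Homo sapiens), with a stated time of 60 min, tested at 0.01 uM, in the presence of a further agent that is not named here (a lower number here means a weaker effect, a higher number a stronger effect of the compound at the concentration tested), compound 1 `COc1ccc(S(=O)(=O)N2CCC(CCC(=O)c3cc(Cl)c(N)cc3OC)CC2)cc1` was reported as "not active" (no number reported), with no number given. Compound 2 `COc1ccc(S(=O)(=O)NCCCN2CCC(CCC(=O)c3cc(Cl)c(N)cc3OC)CC2)cc1` was likewise reported as "not active" (no number reported) in this assay, again with no number given. Among the compounds with values here, compound 3 `COc1cc(N)c(Cl)cc1C(=O)CCC1CCN(CCNS(=O)(=O)c2ccc(NC(C)=O)cc2)CC1` is the only one with a reported figure: in this assay compound 3 gives 7%, which is the sole number in the set, so it cannot be ranked against the others.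

Compound 4 `COc1cc(N)c(Cl)cc1C(=O)CCC1CCN(CCNS(=O)(=O)c2ccc3c(c2)NC(=O)CO3)CC1` differs from compound 3 in one place, on the sulfonyl sulfur whose other neighbour is the sulfonamide nitrogen (a group of 11 heavy atoms (8 carbon, 1 nitrogen, 2 oxygen; one six-membered non-aromatic ring with 2 hetero atoms, one six-membered aromatic ring of carbon only) in place of a group of 10 heavy atoms (8 carbon, 1 nitrogen, 1 oxygen; one six-membered aromatic ring of carbon only), on a sulfonyl sulfur). Within the data shown here, no step between two measured compounds is available to guide the size of this change. Given that compound 3 shows 7%, a step no larger than the usual scatter is expected in this assay, in either direction. The expected step from compound 3 to compound 4 is a number 3 percentage points higher from compound 3 to compound 4 (within the scatter). Compound 4 is therefore estimated to give 10% in this assay, with a plausible span from 0% to 30%.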

Compound 4, a percentage reported as inhibition, at one concentration (the size of the read-out at that concentration, not a potency): "not active" (no number reported)
Compound 4: no number reported, so the estimate cannot be set against anything.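

Within the data shown here, compound 4 carries no number in this assay, so no step from compound 3 to compound 4 can be read, and no other information here bears on this result. Going by these compounds, whether replacing the 4-acetamidophenyl group changes the effect in this assay therefore remains open.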